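Swapping a fluorophenyl for a dihydroindolyl: expected lipophilicity

The source may report more compounds than this note shows. Statements on the series, on what has been measured and on what is new or still open speak of the compounds shown alone.

compound 1 `CNC(=O)c1cc(C(=O)NC2CC2)cn(Cc2ccc(F)cc2)c1=O` 3.2
compound 2 `CNC(=O)c1ccc(=O)n(Cc2ccccc2)c1` 1.6

In a physicochemical assay for lipophilicity, at pH 7.4 (a higher number here means a more lipophilic compound, a lower number a more polar compound), compound 1 holds the higher of the two values, and compound 2 lies beyond the scatter below it. Compound 3 `CNC(=O)c1cc(C(=O)NC2CC2)cn(Cc2cccc3c2CCN3)c1=O` has not yet been measured; it differs from compound 1 by 2,3-dihydro-1H-indol-4-yl in place of 4-fluorophenyl on a saturated chain carbon bound to an aromatic nitrogen. Among the measured compounds shown here, no measured pair shows this exact change, so its effect rests on expectation alone. The value is expected to fall by a modest amount in this assay, a number 0.50 log units lower from compound 1 to compound 3 (beyond the scatter), a step beyond the scatter but leaving compound 3 still above compound 2. Compound 3 is therefore estimated at 2.7, most likely between 2.1 and 3.3.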

Compound 3, distribution coefficient: 2.1
Estimate against measurement, compound 3: 0.60 log units above, and the stated range covers the measured number.
By their numbers in this assay, from the lowest: compound 2; then compound 3; then compound 1.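

In this assay, 2,3-dihydro-1H-indol-4-yl in place of 4-fluorophenyl on a saturated chain carbon bound to an aromatic nitrogen gives a number 1.10 log units lower from compound 1 to compound 3 (beyond the scatter), a large step. This is the first pair shown that differs in one place only, so the change at this position alone accounts for the step. Nothing available explains why the step has this size.

The compounds shown do not separate the loss of fluorine from the arrival of the ring nitrogen. From the compounds shown here alone, how a simple amine or a carboxylic acid at this position would compare remains open.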